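The source may hold more compounds than are shown below. What is called first, only, known or untested is meant among the compounds shown, and "the series" means these compounds.

Compound 1 `CC1(C)CC(NC(=O)NCc2ccccc2)c2cc(Br)ccc2O1` gives 38000 nM
Compound 2 `CC1(C)CC(NC(=O)NCc2ccccc2)c2cc(Cl)ccc2O1` gives 15000 nM
Compound 3 `CC1(C)CC(NC(=O)NCc2ccccc2)c2cc(F)ccc2O1` gives 49000 nM

In a functional assay on T98G cells (Homo sapiens) for inhibition, read by MTT assay, with a stated time of 72 h (a lower number here means a stronger inhibitor, a higher number a weaker inhibitor), compound 2 has the lowest of these three numbers, which makes it the strongest inhibitor of the set. Compound 4 `CC1(C)CC(NC(=O)Nc2cccc(Cl)c2)c2cc(Cl)ccc2O1` has 3-chlorophenyl in place of benzyl on an amide-type nitrogen. The measured steps only swap one halogen for another and never touch this group. Of these, a 2.5-fold lower number from compound 1 to compound 2 (0.40 log units; beyond the scatter) and a 3.3-fold higher number from compound 2 to compound 3 (0.51 log units; beyond the scatter) are both modest, so they guide the size only loosely and say nothing about direction. A similarly small change is expected, tentatively toward a lower number (a 1.7-fold lower number from compound 2 to compound 4 (0.22 log units; within the scatter)). Compound 4 is estimated at 9000 nM with an expected range (3000 nM to 30000 nM).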

Compound 4, half-maximal inhibitory concentration: 25000 nM
For compound 4 the middle estimate is 2.8-fold (0.44 log units) below the measured one; the range from low to high includes it.
By their numbers in this assay, from the lowest: compounds 2, 4, 1 and 3 (each within the scatter of the next, the first and the last beyond it).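

In this assay the change from benzyl to 3-chlorophenyl on an amide-type nitrogen gives a 1.7-fold higher number from compound 2 to compound 4 (0.22 log units; within the scatter) and so leaves the two compounds indistinguishable. Among the compounds shown here, this is the first measured change away from the halogen, and it shows that this group can be replaced without a step beyond the scatter. No measurement at hand explains this result. Still open, on these data alone, is how a plain phenyl or a longer chain such as phenylethyl on this nitrogen would read, and whether the halogen steps repeat with 3-chlorophenyl in place.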